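The compounds below may be only part of what the source reports. "The series", "measured", "known", "first", "only" and "open" are said of these compounds alone.

Of the compounds shown here, three have numbers so far in a functional assay on HepG2 cells (Homo sapiens) for antiproliferative activity, read by MTT assay, with a stated time of 72 h; on this read-out lower numbers stand for stronger inhibition and higher numbers for weaker inhibition. Compound 1 (`COc1cc(CCc2ccncc2)cc(OC)c1O`) gives 2170 nM, compound 2 (`COc1cc(CCc2ccc(F)cc2)cc(OC)c1O`) gives 5470 nM, and compound 3 (`COc1ccc(CCc2ccccc2Cl)cc1OC`) gives 4930 nM. On these numbers compound 2 and compound 3 lie within the usual scatter of each other, so they cannot be told apart. Compound 1 has a lower number than compound 2 by more than the scatter, which means stronger inhibition in this assay.

Compound 4 (`COc1cc(CCc2ccc([N+](=O)[O-])cc2)cc(OC)c1O`) is compound 2 with a single change, nitro in place of fluoro on an aromatic carbon. Within the data shown here, no pair of measured compounds differs in just one place, so nothing measured shows directly what this swap does. The expectation can only start from compound 2 at 5470 nM and from the narrow spread of the three values, whose lowest is compound 1 at 2170 nM. A small move towards a lower number is expected, with nothing beyond the scatter. In estimated terms this is a 1.4-fold lower number from compound 2 to compound 4 (0.14 log units; within the scatter). The estimated value for compound 4 is 4000 nM, with an expected range of 1500 nM to 11000 nM.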

Compound 4, half-maximal inhibitory concentration: 11000 nM
For compound 4 the middle estimate is 2.8-fold (0.44 log units) below the measured one, within the range that was stated.
By their numbers in this assay, from the lowest: compound 1; then compounds 3, 2 and 4 (each within the scatter of the next, the first and the last beyond it).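

In this assay, replacing fluoro with nitro gives a 2.0-fold higher number from compound 2 to compound 4 (0.30 log units; within the scatter), so this first direct comparison cannot tell the two groups apart. The aromatic carbon para to a large group therefore carries either fluoro or nitro without a difference that can be read beyond ordinary measurement variation, even though nitro has more heavy atoms than fluoro and brings hydrogen-bond acceptors that fluoro lacks. No separate measurement is available to explain this result or to link it to any property of either group.

From the compounds shown here alone, one step at one position cannot establish a trend, so it remains open whether an amine, a carboxylic acid or a longer chain at this same place would give a number that differs beyond the scatter. Going by these compounds, it is also open whether swapping fluoro for nitro would have a similarly small effect at another place on the ring or on a different core.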